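Oxygen to sulfur swap on the diamine core

A few compounds are considered here, and "the series" means these few. Any claim that something is new, unique, unknown or untested is made for them only; others in the source may bear on it.

compound 1 `Nc1cc(N)c2nc(-c3ccccc3)c(Oc3ccc(Cl)c(Cl)c3)nc2c1`: 91200 nM
compound 2 `Nc1cc(N)c2nc(-c3ccccc3)c(Oc3ccc(F)cc3)nc2c1`: < 100000 nM

In a functional assay on SW-620 cells (Homo sapiens) for inhibition, read by sulforhodamine B assay, with a stated time of 48 h (a lower number here means that less compound is tolerated, a higher number that more compound is tolerated), compound 1 gives 91200 nM. Compound 2 gives only a limit in this assay, < 100000 nM. The step that the limit leaves unreadable from compound 1 to compound 2 cannot be sized because of the limit of < 100000 nM in this assay, at which 1 of the 2 values shown sits. Compound 3 `Nc1cc(N)c2nc(-c3ccccc3)c(Sc3ccc(F)cc3)nc2c1` differs from compound 2 by (4-fluorophenyl)sulfanyl in place of 4-fluorophenoxy on an aromatic carbon. Going by the values given here, no measured step covers an oxygen-to-sulfur exchange, and the single measured step stays unreadable, so no shift beyond the scatter is assumed. Compound 3 is expected near 70000 nM, within 25000 nM to 150000 nM. The expected step from compound 2 to compound 3 is a step that the limit leaves unreadable from compound 2 to compound 3.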

Compound 3, concentration lethal to 50% of the cells: < 100000 nM
Compound 3: a limit, no number (the forecaster's own chance of this, stated with the estimate: 35%); the middle value lies beyond the limit too.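

The steps from compound 2 to compound 3 and from compound 1 to compound 3 cannot be read in this assay, because compound 3 gives only a limit, < 100000 nM: the limit of < 100000 nM in this assay, at which 2 of the 3 values shown sit.

From the compounds shown here alone, whether (4-fluorophenyl)sulfanyl in place of 4-fluorophenoxy shifts the lethal concentration at all stays open.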